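Taking the Nitro Group Off the Para Position

A few compounds are considered here, and "the series" means these few. Any claim that something is new, unique, unknown or untested is made for them only; others in the source may bear on it.

Compound 3 `O=C1NN(c2ccc([N+](=O)[O-])cc2)C(=O)C2(CSC3=C2C(=O)c2ncccc2C3=O)N1` gives 2 nM in a functional assay on CCRF-SB cells (Homo sapiens) for antiproliferative activity, read by MTT assay, with a stated time of 96 h (a higher number here means a weaker inhibitor, a lower number a stronger inhibitor), level at the digits shown with compound 2 `O=C1C2=C(C(=O)c3ncccc31)C1(CS2)NC(=O)N(c2ccc([N+](=O)[O-])cc2)C1=O`, which gives 2 nM in this assay. Compound 1 `CN(C)c1ccc(N2C(=O)NC3(CSC4=C3C(=O)c3ncccc3C4=O)C2=O)cc1` gives 1 nM in this assay, so all three numbers lie within the scatter of one another. For the measured compounds named here, the one measured step, a 2.0-fold higher number from compound 1 to compound 2 (0.30 log units; within the scatter), concerns the same aromatic position. Compound 4 `O=C1NN(c2ccccc2)C(=O)C2(CSC3=C2C(=O)c2ncccc2C3=O)N1` differs from compound 3 in that place: hydrogen in place of nitro on an aromatic carbon. Since swapping nitro for dimethylamino moved the number only within the scatter, a swap to hydrogen is expected to move it little, with the step of a 1.5-fold higher number from compound 3 to compound 4 (0.18 log units; within the scatter) expected to stay within the scatter. Compound 4 is therefore estimated at 3 nM, between 1 nM and 10 nM.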

Compound 4, half-maximal inhibitory concentration: 39 nM
The estimate for compound 4 lay 13-fold (1.11 log units) below the measured number; the measured number lies above the stated range.
By their numbers in this assay, from the lowest: compounds 1, 2 and 3 (each within the scatter of the next); then compound 4.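

In this assay the removal of the nitro group gives a 20-fold higher number from compound 3 to compound 4 (1.29 log units; beyond the scatter) and so 4-nitrophenyl and phenyl are not interchangeable on this core. The earlier step, a 2.0-fold higher number from compound 1 to compound 2 (0.30 log units; within the scatter), exchanged one group for another on a different core, whereas this change leaves only hydrogen on that aromatic carbon and shows that this place can move the number strongly. Nothing at hand explains the rise. Still open, from the compounds shown here alone, is whether a group other than nitro, such as a primary amine or a methoxy group, keeps the number low at this place on the core of compound 3. Also open, going by these compounds, is whether the same change costs as much on the core of compound 2.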